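The source may report more compounds than this note shows. Statements on the series, on what has been measured and on what is new or still open speak of the compounds shown alone.

Of the compounds shown here, two sharing one core have been tested so far in an ADME assay on CEMx174 cells (Homo sapiens) for cytotoxicity; on this read-out lower numbers stand for higher toxicity in this test and higher numbers for lower toxicity in this test. Compound 1 `CCC1=C(C(=O)OCC2CCCCC2)C(c2ccc(NC(C)=O)cc2)NC(=O)N1` gives > 10000 nM, which is a limit of the assay and not a number. Compound 2 `CCC1=C(C(=O)OCC2CCCCC2)C(c2ccc(N(C)C)cc2)NC(=O)N1` gives > 10000 nM, which is also a limit and not a number. Compound 2 therefore has no exact position on this scale, and the evidence so far amounts to the limit of > 10000 nM in this assay, at which 2 of the 2 values shown sit.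

The next compound is compound 3 `CCC1=C(C(=O)OCC2CCCCC2)C(c2ccc(C(=O)OC)cc2)NC(=O)N1`, which carries methoxycarbonyl in place of dimethylamino on an aromatic carbon, para to a large group: methoxycarbonyl in place of dimethylamino on an aromatic carbon. For the measured compounds named here, the only measured change at that place is a step that the two limits leave unreadable from compound 1 to compound 2. It offers no size to carry over, but it does show two different groups there ending at the same limit. On that basis, no step beyond the usual scatter is expected in this assay, in either direction. The estimated step is a step that the limit leaves unreadable from compound 2 to compound 3. For compound 3 the expected value is 15000 nM, with an estimated range from 6000 nM to 40000 nM.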

Compound 3, half-maximal cytotoxic concentration: > 10000 nM
Compound 3: no number, only a limit (the forecaster's own chance of this, stated with the estimate: 85%); the middle value does not contradict the limit.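

In this assay compound 3 gives > 10000 nM, which is a limit of the assay and not a number. The steps among compound 1, compound 2 and compound 3 therefore cannot be read. Still open, on these data alone, is how far apart these three compounds lie, and whether any group at this place would give a measurable number.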